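The source may hold more compounds than are shown below. What is called first, only, known or untested is meant among the compounds shown, and "the series" means these compounds.

Working notes on the series.

The three measured compounds share the bromopyridinyl amide end and differ in the core and in the acyl group on the amide-type nitrogen. Compound 2 `O=C(CSc1nnc(NC(=O)CCCl)s1)Nc1ccc(Br)cn1` carries a 2-chloroethyl on that carbonyl carbon; in a functional assay on NCI-H460 cells (Homo sapiens) for antiproliferative activity, read by MTT assay, with a stated time of 48 h (a higher number here means a weaker inhibitor, a lower number a stronger inhibitor), compound 2 gives 560 nM. Compound 1 `O=C(CSc1nnc(NC(=O)C(Cl)Cl)s1)Nc1ccc(Br)cn1` is the matched partner, with dichloromethyl in place of 2-chloroethyl on a carbonyl carbon; in this assay compound 1 gives 5300 nM. The step is a 9.5-fold higher number from compound 2 to compound 1 (0.98 log units; beyond the scatter), so on this core the exchange clearly weakens the inhibitor.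

Compound 3 `O=C(CCCl)Nc1ccc(SCC(=O)Nc2ccc(Br)cn2)cc1` keeps the 2-chloroethyl acyl group but sits on a different core; the difference between the core of compound 3 and the core of compound 2 is not broken down here. In this assay compound 3 gives 1600 nM, which places it between compound 2 and compound 1.

Compound 4 `O=C(CSc1ccc(NC(=O)C(Cl)Cl)cc1)Nc1ccc(Br)cn1` is the untested partner of compound 3, with dichloromethyl in place of 2-chloroethyl on a carbonyl carbon. The place lines read identically for both pairs, so this is the same change as from compound 2 to compound 1, made on a different core. The expectation rests on a single precedent, and the core change from compound 2 to compound 3 is not decomposed, so the transfer is uncertain. Going by the values given here, still, the one observed step was well beyond the scatter, and the working estimate for compound 4 is a 7.5-fold higher number from compound 3 to compound 4 (0.88 log units; beyond the scatter), a weakening of similar direction though tempered for the new core. Compound 4 is accordingly expected to give 12000 nM in this assay, with a plausible range from 4000 nM to 40000 nM.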

Compound 4, half-maximal inhibitory concentration: 47800 nM
Estimate against measurement, compound 4: 4.0-fold (0.60 log units) below; measured number above the stated range.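

In this assay, dichloromethyl in place of 2-chloroethyl on a carbonyl carbon gives a 30-fold higher number from compound 3 to compound 4 (1.48 log units; beyond the scatter), so the exchange weakens the inhibitor on the core of compound 3 as it does on the core of compound 2. The direction therefore carries from one core to the other, but the size does not: the same change on two cores in this assay, a 9.5-fold higher number (0.98 log units; beyond the scatter) from compound 2 to compound 1 and a 30-fold higher number (1.48 log units; beyond the scatter) from compound 3 to compound 4, 3.2-fold (0.50 log units) apart, beyond the scatter of two such steps These two matched pairs show that the cost of this exchange cannot be taken as a fixed amount in this series; they do not show why it differs between the cores, and they say nothing about the direction or size of the step on any further core.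

Open, from the compounds shown here alone, is whether the two cores also part ways with other groups on that carbonyl carbon, such as chloromethyl, trichloromethyl or a plain ethyl, which would show whether the difference is tied to this one exchange or appears more generally. Also open, going by these compounds, is which part of the difference between the core of compound 2 and the core of compound 3 goes with the larger step, as that difference is not broken down into single changes here.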